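Removing the aryl methyl: compound 3 to compound 4

This account rests on a few compounds, and the source may have more. Where it says the series, first, only, none or still open, it means among the compounds named here.

Measured compounds in the series:
compound 1, `CCc1nn2c(-c3c(C)cc(OC)cc3OC)cccc2c1N(CC1CCOCC1)CC1CC1`, gives 40 nM in an assay on HEK293 cells for displacement of a labelled ligand from corticotropin-releasing factor receptor 1 (Homo sapiens), read by scintillation counting, with a stated time of 2 h; on this read-out lower numbers stand for stronger inhibition and higher numbers for weaker inhibition.
compound 2, `CCc1nn2c(-c3c(C)cc(C)cc3OC)cccc2c1N(CC1CCOCC1)CC1CC1`, gives 22 nM in this assay.
compound 3, `CCc1nn2c(-c3c(OC)cc(C)cc3OC)cccc2c1N(CC1CCOCC1)CC1CC1`, gives 22 nM in this assay.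

Compound 3 stands level with compound 2 at the digits shown, the two together being the lowest of the three numbers; the step of no change at the digits printed from compound 2 to compound 3 (within the scatter) reads as no change, and the step of a 1.8-fold lower number from compound 1 to compound 3 (0.26 log units; within the scatter) is likewise within the scatter, compound 1 being the furthest of the three.

Compound 4, `CCc1nn2c(-c3c(OC)cccc3OC)cccc2c1N(CC1CCOCC1)CC1CC1`, differs from compound 3 by hydrogen in place of methyl on an aromatic carbon, the site sitting meta to two methoxy groups and para to a large group. Among the measured compounds shown here, no measured step removes this methyl outright. The steps that come nearest are the exchanges of methyl and methoxy on the same ring, a 1.8-fold lower number from compound 1 to compound 2 (0.26 log units; within the scatter) and no change at the digits printed from compound 2 to compound 3 (within the scatter), and the combined rearrangement a 1.8-fold lower number from compound 1 to compound 3 (0.26 log units; within the scatter); none of them moved beyond the scatter. On that basis the step of a 1.3-fold higher number from compound 3 to compound 4 (0.10 log units; within the scatter) is expected to stay within the scatter, with no clear direction. Compound 4 is therefore estimated at 28 nM in this assay, with a range from 10 nM to 80 nM.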

Compound 4, half-maximal inhibitory concentration: 105 nM
Beside the measured number, compound 4's estimate is 3.8-fold (0.57 log units) below it, and the stated range ends below it.
By their numbers in this assay, from the lowest: compounds 2, 3 and 1 (each within the scatter of the next); then compound 4.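

Going from 2,6-dimethoxy-4-methylphenyl to 2,6-dimethoxyphenyl gives a 4.8-fold higher number from compound 3 to compound 4 (0.68 log units; beyond the scatter) in this assay and is the first single change in the series to move beyond the scatter, so this site is not indifferent to losing its substituent. Compound 4 also separates from the other two, with a 4.8-fold higher number from compound 2 to compound 4 (0.68 log units; beyond the scatter) and a 2.6-fold higher number from compound 1 to compound 4 (0.42 log units; beyond the scatter) as the steps, while the compounds carrying methyl or methoxy at this site stay within the scatter of one another. No measurement shown gives a reason for this loss.

On these data alone, it remains open whether a group other than methyl or methoxy, such as fluorine, ethyl or a carboxylic acid, would match compound 3 or compound 4 at this site. Also open, as far as these compounds go, is whether hydrogen here costs as much when the two methoxy groups are replaced.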